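From furan-2-yl to pyridin-2-yl, without a starting number

The source may hold more compounds than are shown below. What is called first, only, known or untested is meant among the compounds shown, and "the series" means these compounds.

In a toxicity assay on J774.A1 cells (Mus musculus) for cytotoxicity, read by SYBR Green assay, with a stated time of 1 h (a higher number here means that more compound is needed for the effect, a lower number that less compound is needed), compound 1 `CN(C)c1ccc2cc(-c3ccccc3)c(N)nc2c1` gives 4900 nM and compound 2 `CN(C)c1ccc2cc(-c3cccc(Cl)c3)c(N)nc2c1` gives 13000 nM. Compound 3 `CN(C)c1ccc2cc(-c3ccco3)c(N)nc2c1` offers no number to start from, as its entry reads "not determined" (no result reported). Compound 4 `CN(C)c1ccc2cc(-c3ccccn3)c(N)nc2c1` differs from compound 3 by one change: pyridin-2-yl in place of furan-2-yl on an aromatic carbon.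

Among the compounds with values here, the only measured step is a 2.7-fold higher number from compound 1 to compound 2 (0.42 log units; beyond the scatter). This modest step lies beyond the scatter, but it concerns chloro in place of hydrogen on an aromatic carbon, so it bears on the present change only indirectly. With no value for compound 3, neither a size nor a direction can be expected for this step in this assay. The estimate must instead lean on the two measured compounds, which also carry a six-membered aromatic ring at this place: compound 1 at 4900 nM and compound 2 at 13000 nM. For compound 4 the expected value is 8000 nM, with an estimated range of 3000 nM to 25000 nM.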

Compound 4, half-maximal effective concentration: 2200 nM
Compound 4: the middle estimate sits 3.6-fold (0.56 log units) above what was measured; the measured number lies below the stated range.
By their numbers in this assay, from the lowest: compound 4; then compound 1; then compound 2.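

In this assay, within the data shown here, pyridin-2-yl gives the lowest number so far at this place on the ring, ortho to the amino group: a 2.2-fold lower number from compound 1 to compound 4 (0.35 log units; beyond the scatter) and a 5.9-fold lower number from compound 2 to compound 4 (0.77 log units; beyond the scatter) are both beyond the scatter. Among these compounds, the only step known before had gone upward with chloro, whereas the number can now be seen to move in either direction from compound 1 when the six-membered aromatic ring at this place is altered. The steps from compound 3 cannot be read, leaving the furan-2-yl to pyridin-2-yl change without a size or direction, and no measurement offered here accounts for the shifts that can be read.

On these data alone, how a five-membered aromatic ring compares at this place remains open. So does how the number would respond to a thiophene ring, or to a phenyl ring carrying an amine or a carboxylic acid.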